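Trimming a Cyclohexyl Amide to Isopropyl on a Shared Core

The source may hold more compounds than are shown below. What is called first, only, known or untested is meant among the compounds shown, and "the series" means these compounds.

Of the compounds shown here, three built on one core have been measured in an assay on isolated protein with Bile acid receptor (Homo sapiens) as the target; a higher number here means that more compound is needed for the effect, a lower number that less compound is needed. Compound 1 `COC(=O)/C=C/c1cccc(N(Cc2ccc(/C=C/c3cccc(C(F)(F)F)c3)cc2)C(=O)C(C)C)c1` gives 267 nM, compound 2 `COC(=O)/C=C/c1cccc(N(Cc2ccc(/C=C/c3c(C)cc(C)cc3C)cc2)C(=O)C(C)C)c1` gives 149 nM, and compound 3 `COC(=O)/C=C/c1cccc(N(Cc2ccc(/C=C/c3scnc3C)cc2)C(=O)C2CCCCC2)c1` gives 227 nM. Compound 3 stands second highest of the three; its gap to compound 1 and its gap to compound 2 both lie within the scatter, so none of the three can be called more or less potent than another. Among the measured compounds shown here, the only single-site step measured so far, a 1.8-fold lower number from compound 1 to compound 2 (0.25 log units; within the scatter), concerns the aryl end of the molecule and also sits within the scatter.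

Compound 4 `COC(=O)/C=C/c1cccc(N(Cc2ccc(/C=C/c3scnc3C)cc2)C(=O)C(C)C)c1` differs from compound 3 in one place: isopropyl in place of cyclohexyl on a carbonyl carbon. For the measured compounds named here, no measured step bears on this change directly. Compounds 1 and 2 already carry the isopropyl group on the carbonyl carbon and sit within the scatter of compound 3, so no shift beyond the scatter is expected from compound 3 to compound 4, which is estimated as a 1.0-fold higher number from compound 3 to compound 4 (0.01 log units; within the scatter). Compound 4 is therefore expected to give about 230 nM, in a range from 100 nM to 500 nM in this assay.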

Compound 4, half-maximal effective concentration: 228 nM
Compound 4: the middle estimate sits 1.0-fold (0.00 log units) above what was measured, and the stated range covers the measured number.
By their numbers in this assay, from the lowest: compounds 2, 3, 4 and 1 (each within the scatter of the next).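

Replacing cyclohexyl with isopropyl on a carbonyl carbon gives a 1.0-fold higher number from compound 3 to compound 4 (0.00 log units; within the scatter) in this assay, so with the 4-methyl-1,3-thiazol-5-yl group in place, the six-membered ring is not needed to keep the number in this range. With isopropyl held constant, 4-methyl-1,3-thiazol-5-yl in place of 2,4,6-trimethylphenyl gives a 1.5-fold higher number from compound 2 to compound 4 (0.18 log units; within the scatter) and in place of 3-(trifluoromethyl)phenyl gives a 1.2-fold lower number from compound 1 to compound 4 (0.07 log units; within the scatter) on the same scale, so these three end groups cannot be told apart. Nothing at hand explains why these changes leave the number within the scatter.

Going by these compounds, it remains open whether a methyl group or an amine on the carbonyl carbon would move the number beyond the scatter. The compounds shown also do not reveal whether cyclohexyl and isopropyl would match when paired with 2,4,6-trimethylphenyl or 3-(trifluoromethyl)phenyl.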